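A Sulfonyl Group Returns on the Aromatic Part

The source may report more compounds than this note shows. Statements on the series, on what has been measured and on what is new or still open speak of the compounds shown alone.

For the measured compounds named here, compound 2 `CC(C)(N)C(=O)N[C@H](COCc1ccccc1)c1nnnn1CCCc1ccccc1` gives 17 nM in a functional assay on H4 cells for agonist activity at growth hormone secretagogue receptor type 1 (Homo sapiens), read by FLIPR (a lower number here means that less compound is needed, a higher number that more compound is needed for the effect), the lower of the two numbers measured so far. Compound 1 `CC(C)(N)C(=O)N[C@H](COCc1ccccc1)c1nnnn1Cc1ccc(NS(C)(=O)=O)cc1` gives 259 nM in this assay. Going by the values given here, the single measured step, a 15-fold lower number from compound 1 to compound 2 (1.18 log units; beyond the scatter), was large and beyond the scatter. Compound 3 `CN(c1ccccc1CCCn1nnnc1[C@@H](COCc1ccccc1)NC(=O)C(C)(C)N)S(C)(=O)=O` differs from compound 2 by methyl(methylsulfonyl)amino in place of hydrogen on an aromatic carbon; cut one bond further out, phenyl becomes 2-(methyl(methylsulfonyl)amino)phenyl. As far as these compounds go, that step bears only loosely on the new change: compound 1 also carried a sulfonyl group on its aromatic part, but the step to compound 2 removed it and lengthened the chain at the same time, so the effect of the sulfonyl group alone stays unknown. The expected step is therefore a 2.6-fold higher number from compound 2 to compound 3 (0.42 log units; beyond the scatter), a modest rise with wide uncertainty. Compound 3 is estimated at 45 nM, within a range from 10 nM to 200 nM.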

Compound 3, half-maximal effective concentration: 14 nM
Compound 3: the middle estimate sits 3.2-fold (0.51 log units) above what was measured, within the range that was stated.
By their numbers in this assay, from the lowest: compounds 3 and 2 (each within the scatter of the next); then compound 1.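

Placing methyl(methylsulfonyl)amino on this aromatic carbon, ortho to a large group, gives a 1.2-fold lower number from compound 2 to compound 3 (0.08 log units; within the scatter) in this assay, so the two compounds cannot be told apart. This position therefore accepts a substituent of 6 heavy atoms without a measurable loss, which the earlier pair could not show, since the step between compound 1 and compound 2 changed both the sulfonyl-bearing aromatic part and the chain at once. No separate measurement is available that bears on this result.

The compounds shown leave open whether other groups on the same carbon, such as an amine or a carboxylic acid, would be accepted equally well. They also leave open how methyl(methylsulfonyl)amino would behave on a different carbon of this ring or with a longer chain.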